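This account rests on a few compounds, and the source may have more. Where it says the series, first, only, none or still open, it means among the compounds named here.

Measured compounds:
Compound 1, `CCOC(=O)C[C@H]1[C@@H](O[Si](C)(C)C(C)(C)C)[C@H](n2cnc3c(NC(=O)Nc4ccccc4)ncnc32)O[C@@H]1COC(=O)NC`, gives 2.83 nM in a functional assay on SF-295 cells (Homo sapiens) for antiproliferative activity; a lower number here means a stronger inhibitor of growth, a higher number a weaker inhibitor of growth.
Compound 2, `CNC(=O)NC[C@H]1O[C@@H](n2cnc3c(NC(=O)Nc4ccccc4)ncnc32)[C@H](O[Si](C)(C)C(C)(C)C)[C@@H]1CC(=O)N(C)OC`, gives 9.09 nM in this assay.

Among the two numbers, compound 2 has the higher one, and the nearest value, that of compound 1, lies beyond the usual scatter below it; the two structures differ in more than one place, so their values are simply compared, not explained. Compound 3, `CCOC(=O)C[C@H]1[C@@H](O[Si](C)(C)C(C)(C)C)[C@H](n2cnc3c(NC(=O)Nc4ccccc4)ncnc32)O[C@@H]1CNC(=O)NC`, is the unmeasured partner of compound 2. The change is ethoxy in place of methoxy(methyl)amino on a carbonyl carbon. Among the compounds with values here, no step between measured compounds shows what this exchange does on its own, so the expected step is worded cautiously. Compound 3 is expected to show a modest move toward a lower number, a 2.0-fold lower number from compound 2 to compound 3 (0.31 log units; beyond the scatter), of a size that may not clear the scatter, because compound 1, which also carries the ethoxycarbonyl group, gives 2.83 nM. Compound 3 is estimated at 4.5 nM, with a range from 1.5 nM to 13 nM.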

Compound 3, concentration for 50% growth inhibition: 5.73 nM
Compound 3: middle estimate off by 1.3-fold (0.10 log units), on the low side, and the stated range covers the measured number.
By their numbers in this assay, from the lowest: compound 1; then compounds 3 and 2 (each within the scatter of the next).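

Compound 3 separates the two places in which compounds 1 and 2 differ. At the carbonyl carbon, ethoxy in place of methoxy(methyl)amino gives a 1.6-fold lower number from compound 2 to compound 3 (0.20 log units; within the scatter) in this assay, so this exchange alone has no effect that can be told from the scatter. On the saturated chain carbon bound to a saturated ring carbon, (methylcarbamoyl)amino in place of (methylcarbamoyl)oxy gives a 2.0-fold higher number from compound 1 to compound 3 (0.31 log units; beyond the scatter), a modest step that does clear the scatter, although nothing available explains either result.

The compounds shown leave open whether a carboxylic acid or a longer ester chain at the carbonyl carbon would also stay within the scatter. They also leave open how a simple amine at the chain carbon would compare with the (methylcarbamoyl)amino group.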